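The compounds below may be only part of what the source reports. "The series", "measured", "known", "first", "only" and "open" are said of these compounds alone.

Measured compounds in the series:

compound 1 `COc1ncc(-c2ccc3ncnc(Nc4ccc(OCCCO)nc4)c3c2)cc1NS(=O)(=O)c1ccc(F)cc1F` — 9360 nM
compound 2 `COc1ncc(-c2ccc3ncnc(Nc4cnn(CCCO)c4)c3c2)cc1NS(=O)(=O)c1ccc(F)cc1F` — 4830 nM

Both numbers come from a functional assay on A549 cells (Homo sapiens) for antiproliferative activity, read by sulforhodamine B assay, with a stated time of 72 h; on this read-out lower numbers stand for stronger inhibition and higher numbers for weaker inhibition. Among the measured compounds shown here, compound 2 holds the lower of the two numbers, with compound 1 the only neighbour; the step of a 1.9-fold lower number from compound 1 to compound 2 (0.29 log units; within the scatter) lies within the scatter, so the two compounds are not separated on this read-out.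

Compound 3 `COc1ncc(-c2ccc3ncnc(Nc4ccc(OCCO)nc4)c3c2)cc1NS(=O)(=O)c1ccc(F)cc1F` has not been measured. Relative to compound 2 it carries 6-(2-hydroxyethoxy)pyridin-3-yl in place of 1-(3-hydroxypropyl)-1H-pyrazol-4-yl on a nitrogen on an aromatic ring. For the measured compounds named here, this reverses the only measured step, with the difference that the hydroxyalkoxy chain on the pyridine is one carbon shorter than in compound 1. Going by the values given here, the sole bearing step, a 1.9-fold lower number from compound 1 to compound 2 (0.29 log units; within the scatter), was within the scatter; nothing speaks to the length of the chain on the pyridine oxygen. The expected step of a 1.7-fold higher number from compound 2 to compound 3 (0.22 log units; within the scatter) is therefore a return towards the number of compound 1 and is not expected to exceed the scatter. Compound 3 is estimated at 8000 nM in this assay, with a range of 3500 nM to 18000 nM.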

Compound 3, half-maximal inhibitory concentration: 4120 nM
The estimate for compound 3 lay 1.9-fold (0.29 log units) above the measured number; the measured number falls inside the stated range.
By their numbers in this assay, from the lowest: compounds 3, 2 and 1 (each within the scatter of the next, the first and the last beyond it).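

In this assay, among the compounds shown here, replacing 6-(3-hydroxypropoxy)pyridin-3-yl with 6-(2-hydroxyethoxy)pyridin-3-yl on the aromatic nitrogen gives a 2.3-fold lower number from compound 1 to compound 3 (0.36 log units; beyond the scatter), the first step to clear the scatter, though only modestly, and it shows that the chain on the pyridine oxygen can register at this position. By contrast, exchanging 1-(3-hydroxypropyl)-1H-pyrazol-4-yl for 6-(2-hydroxyethoxy)pyridin-3-yl gives a 1.2-fold lower number from compound 2 to compound 3 (0.07 log units; within the scatter), so this pair is not separated on this read-out despite the different ring and chain. No supporting data bear on the reason for either result.

A single chain change cannot show whether the response to chain length continues, and a pyridine carrying a longer hydroxyalkoxy chain or a simple methoxy group would test that. On these data alone, it also remains open whether the terminal hydroxy matters at all, which could be examined by replacing it with an amine or a carboxylic acid on either ring, or by moving to a 2-hydroxyethyl chain on the pyrazole.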